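Working notes: one added chloro on compound 1

The source may hold more compounds than are shown below. What is called first, only, known or untested is meant among the compounds shown, and "the series" means these compounds.

Measured in a functional assay on A549 cells (Homo sapiens) for antiproliferative activity, read by MTT assay, with a stated time of 48 h; on this read-out higher numbers stand for weaker inhibition and lower numbers for stronger inhibition:
compound 1 `O=[N+]([O-])c1cc(C(F)(F)F)cc([N+](=O)[O-])c1Oc1ccc(Cl)cc1/C=N\OCc1ccccc1`: 3410 nM
compound 2 `O=[N+]([O-])c1cc(C(F)(F)F)cc([N+](=O)[O-])c1Oc1ccc(Cl)cc1/C=N\OCc1ccc(Cl)cc1Cl`: 3440 nM

In this assay, within the data shown here, compound 1 gives 3410 nM and stands level with compound 2, the only other measured compound, so no order can be read between the two. Compound 3 `O=[N+]([O-])c1cc(C(F)(F)F)cc([N+](=O)[O-])c1Oc1c(Cl)cc(Cl)cc1/C=N\OCc1ccccc1` keeps the core of compound 1 and differs by one change: chloro in place of hydrogen on an aromatic carbon. Here chloro takes the place of hydrogen on an aromatic carbon, ortho to a large group, meta to a chloro group and meta to a large group.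

Among the measured compounds shown here, no measured step covers this place. For the measured compounds named here, the only step available is a 1.0-fold higher number from compound 1 to compound 2 (0.00 log units; within the scatter), which places 2,4-dichlorophenyl in place of phenyl on a saturated chain carbon bound to an oxygen. It lies elsewhere in the molecule, so it is only a weak guide. Since that step stays within the scatter, no step beyond the scatter is expected in this assay, and no direction can be assigned. The expected change is a 1.1-fold lower number from compound 1 to compound 3 (0.06 log units; within the scatter). Compound 3 is estimated at 3000 nM, with an expected range of 1300 nM to 7000 nM.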

Compound 3, half-maximal inhibitory concentration: 1450 nM
Compound 3: the middle estimate sits 2.1-fold (0.32 log units) above what was measured, within the range that was stated.
By their numbers in this assay, from the lowest: compound 3; then compounds 1 and 2 (each within the scatter of the next).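

In this assay, chloro in place of hydrogen on an aromatic carbon, ortho to a large group, meta to a chloro group and meta to a large group, gives a 2.4-fold lower number from compound 1 to compound 3 (0.37 log units; beyond the scatter), a modest step towards stronger inhibition. Among these compounds, the earlier pair showed no such movement: a 1.0-fold higher number from compound 1 to compound 2 (0.00 log units; within the scatter), so a change elsewhere in the molecule left the number level, while this aromatic carbon is the first place where one change moves the number beyond the scatter. No measured data on the compounds explain this step.

The compounds shown leave open whether this step is particular to chloro or would also appear with another group on the same carbon, such as fluoro, bromo, methyl or methoxy. They also leave open whether chloro at this place adds to the 2,4-dichlorophenyl of compound 2 in a single molecule, and whether the step holds beyond this one cell line and read-out.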